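Swapping a sulfonamide for an amide on the shared core

The compounds below may be only part of what the source reports. "The series", "measured", "known", "first", "only" and "open" are said of these compounds alone.

Of the compounds shown here, three sharing one core have been measured in an in vitro ADME assay on microsomes from liver (Homo sapiens) for metabolic stability; on this read-out higher numbers stand for fast clearance and lower numbers for slow clearance. Compound 1, `CNS(=O)(=O)c1ccc(-c2cnc(N)c(-c3ccc(OC)nc3)c2)cc1`, gives 9.6 mL.min-1.g-1; compound 2, `COc1ccc(-c2cc(-c3ccc(-n4cncn4)cc3)cnc2N)cn1`, gives 8 mL.min-1.g-1; compound 3, `COc1ccc(-c2cc(-c3ccc4cnn(C)c4c3)cnc2N)cn1`, gives 12 mL.min-1.g-1. Compound 1 sits second highest of the three, yet all three lie within the scatter of one another, so no order can be read from them. The unmeasured compound 4, `COc1ccc(-c2cc(-c3ccc(C(N)=O)cc3)cnc2N)cn1`, differs from compound 1 in one place: carbamoyl in place of methylsulfamoyl on an aromatic carbon. Among the measured compounds shown here, the only comparable step is the one from compound 1 to compound 2, where another group replaced the methylsulfamoyl, and it moved this assay by a 1.2-fold lower number from compound 1 to compound 2 (0.08 log units; within the scatter). No step beyond the scatter is therefore expected in this assay for compound 4. The expectation is a 1.1-fold lower number from compound 1 to compound 4 (0.03 log units; within the scatter), giving compound 4 an estimated 9 mL.min-1.g-1, within 4.5 mL.min-1.g-1 to 18 mL.min-1.g-1.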

Compound 4, intrinsic clearance in microsomes: < 7 mL.min-1.g-1
Compound 4 was reported as a limit; the forecaster's own chance of this, stated with the estimate: 5%; middle value at least 1.2-fold (0.10 log units) away from the limit.
By their numbers in this assay, from the lowest: compounds 2, 1 and 3 (each within the scatter of the next). At a limit, below all of these: compound 4.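

At the place para to a large group, carbamoyl brings the first result in this assay that is not a plain number: compound 4 is reported as < 7 mL.min-1.g-1, which is a limit. The change gives an at least 1.3-fold lower number from compound 1 to compound 4 (0.13 log units; that floor lies within the scatter), and an at least 1.1-fold lower number from compound 2 to compound 4 (0.05 log units; that floor lies within the scatter). Only these floors are known, so the real size of either step cannot be read, because the result is a limit: the limit of < 7 mL.min-1.g-1 in this assay, at which 1 of the 4 values shown sits.

From the compounds shown here alone, it remains open whether a methylcarbamoyl, a nitrile or a carboxylic acid at this place would also reach the limit.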